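Swapping the Outer Ring on a Sulfonamide Piperidine

The compounds below may be only part of what the source reports. "The series", "measured", "known", "first", "only" and "open" are said of these compounds alone.

Compound 1 `Cc1cc(C)c(S(=O)(=O)N2CCC(N3CCN(C)CC3)CC2)c(C)c1` is examined in a functional assay on DLD-1 cells (Homo sapiens) for antiproliferative activity, read by CellTiter-Glo, with a stated time of 72 h (on this read-out lower numbers stand for stronger inhibition and higher numbers for weaker inhibition), where compound 1 gives 1100 nM. Compound 2 `Cc1cc(C)c(S(=O)(=O)NC2CCN(C3CCN(C)CC3)CC2)c(C)c1`, a close relative, gives 958 nM in this assay, and the two values lie within the usual scatter of each other. Compound 3 `Cc1cc(C)c(S(=O)(=O)N2CCC(N3CCC(O)CC3)CC2)c(C)c1` has not been measured. It differs from compound 1 in one place: 4-hydroxypiperidin-1-yl in place of 4-methylpiperazin-1-yl on a saturated ring carbon. For the measured compounds named here, no measured pair shows this particular change, so only a modest step is expected, if any, probably toward weaker inhibition. The estimate for compound 3 in this assay is 1500 nM, within a range from 500 nM to 4500 nM, which means an expected step of a 1.4-fold higher number from compound 1 to compound 3 (0.13 log units; within the scatter) that stays close to the scatter.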

Compound 3, half-maximal inhibitory concentration: 106 nM
Beside the measured number, compound 3's estimate is 14-fold (1.15 log units) above it; the whole stated range lies above it.
By their numbers in this assay, from the lowest: compound 3; then compounds 2 and 1 (each within the scatter of the next).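

In this assay, the group on this saturated ring carbon proves to matter: 4-hydroxypiperidin-1-yl in place of 4-methylpiperazin-1-yl gives a 10-fold lower number from compound 1 to compound 3 (1.02 log units; beyond the scatter), a large step from a swap that keeps the ring size. Before this result, no change at this place could be read. No measurement here accounts for the step.

Still open, going by these compounds, is which part of the swap counts: gaining the hydroxyl or losing the methyl-bearing ring nitrogen. A plain piperidin-1-yl or a 4-aminopiperidin-1-yl group at this place would help separate the two.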